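A few compounds are considered here, and "the series" means these few. Any claim that something is new, unique, unknown or untested is made for them only; others in the source may bear on it.

Compound 1 `Cc1nn(-c2ncnc3nc[nH]c23)c2c1C(OCc1ccc(Cl)cc1Cl)CC(=O)N2` sets the reference point here. In a functional assay on HEK293 cells for agonist activity at G-protein coupled receptor 39 (Homo sapiens), read by scintillation proximity assay and inositol phosphate accumulation, with a stated time of 75 min, in the presence of a further agent that is not named here (a higher number here means that more compound is needed for the effect, a lower number that less compound is needed), compound 1 gives 4 nM, the lowest of the three numbers recorded. Within the data shown here, compound 2 `Cc1nn(-c2ncnc3nc[nH]c23)c2c1C(C(=O)Nc1ccccc1)CC(=O)N2` in this assay gives 10 nM, and the single direct comparison available is a 2.5-fold higher number from compound 1 to compound 2 (0.40 log units; beyond the scatter), the replacement of the whole side group by another. Compound 3 `C=CCN1c2c(n(C)c(=O)n(C)c2=O)NC1N/N=C/c1ccc(O)cc1O`, built on a different core, gives 340 nM in this assay, far from compound 1.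

Compound 4 `Cc1nn(-c2ncnc3nc[nH]c23)c2c1C(OCc1cc(F)cc3c1OCOC3)CC(=O)N2` keeps the core of compound 1 and its connecting oxygen and changes only the aromatic portion beyond it: a group of 11 heavy atoms (8 carbon, 2 oxygen, 1 fluorine; one six-membered non-aromatic ring with 2 hetero atoms, one six-membered aromatic ring of carbon only) in place of a group of 8 heavy atoms (6 carbon, 2 chlorine; one six-membered aromatic ring of carbon only), on a saturated chain carbon bound to an oxygen on a saturated carbon. Among the measured compounds shown here, no measured step touches this ring directly. The step from compound 1 to compound 2, which swapped out a larger part of the molecule, moved the number by a modest amount, so a similarly modest shift, likely toward a higher number, is expected for compound 4 in this assay, though a change within the scatter cannot be excluded. Compound 4 is therefore estimated at 10 nM, with a range from 3 nM to 40 nM, corresponding to an expected step of a 2.5-fold higher number from compound 1 to compound 4 (0.40 log units; beyond the scatter).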

Compound 4, half-maximal effective concentration: 1.5 nM
Compound 4: middle estimate off by 6.7-fold (0.82 log units), on the high side, outside the stated range (below it).
By their numbers in this assay, from the lowest: compound 4; then compound 1; then compound 2; then compound 3.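

With the connecting oxygen kept, the change from the 2,4-dichlorophenyl group to the larger group carrying fluorine and a six-membered non-aromatic ring gives a 2.7-fold lower number from compound 1 to compound 4 (0.43 log units; beyond the scatter) in this assay. The earlier step had shown only a higher number on replacing the whole side group, whereas this one shows that the number can also fall at this place, and that a low number among these compounds does not require either chlorine. No measured information bears on the reason for this step.

The fluorine and the non-aromatic ring enter together, so the compounds shown do not separate their contributions. Also open, going by these compounds, is how this assay would read an amine or a carboxylic acid on the aromatic ring at this place.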